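A few compounds are considered here, and "the series" means these few. Any claim that something is new, unique, unknown or untested is made for them only; others in the source may bear on it.

Of the compounds shown here, three sharing one core have been measured in a functional assay on the whole organism with Canis familiaris (Canis lupus familiaris) as the target, at a dose of 8 mg/kg by the oral route; on this read-out higher numbers stand for a stronger effect at the one dose given and lower numbers for a weaker effect. Compound 1 `Cc1nc2c(OCc3ccccc3)cccn2c1N`, which carries both a methyl group and an amino group, gives 96%. Compound 2 `Nc1cnc2c(OCc3ccccc3)cccn12` keeps the amino group but not the methyl, and compound 2 gives 43%; the step of a number 53 percentage points lower from compound 1 to compound 2 (beyond the scatter) came with hydrogen in place of methyl on an aromatic carbon. Compound 3 `Cc1nc2c(OCc3ccccc3)cccn2c1CN` keeps the methyl but carries aminomethyl where compound 1 carries amino, and compound 3 gives 9%. On these numbers compound 3 stands lowest of the three, beyond the scatter below compound 2 and far below compound 1, the distance being a number 87 percentage points lower from compound 1 to compound 3 (beyond the scatter).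

The next step leads to compound 4 `CC(=O)Nc1c(C)nc2c(OCc3ccccc3)cccn12`, which differs from compound 3 by acetamido in place of aminomethyl on an aromatic carbon. The methyl is kept, so the step from compound 1 to compound 2 does not bear directly on it. The step from compound 1 to compound 3 does bear: it shows how much was lost when amino gave way to aminomethyl, and acetamido is amino with an acetyl added, so compound 4 resembles compound 1 more closely than compound 3 does. Among the compounds with values here, no measured compound shows what the acetyl itself costs. A step upward is therefore expected in this assay, of uncertain size, estimated at a number 41 percentage points higher from compound 3 to compound 4 (beyond the scatter). Compound 4 is expected to give about 50%, within a range from 10% to 90%.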

Compound 4, a percentage reported as inhibition, in the whole organism at one dose (the size of the read-out at that dose, not a potency): 44%
Estimate against measurement, compound 4: 6 percentage points above; the range from low to high includes it.
By their numbers in this assay, from the lowest: compound 3; then compounds 2 and 4 (each within the scatter of the next); then compound 1.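

In this assay, the step of a number 35 percentage points higher from compound 3 to compound 4 (beyond the scatter) came with acetamido in place of aminomethyl on this aromatic carbon, so the two groups, which have the same hydrogen-bond donor and acceptor counts, still give clearly different read-outs at this position. The step of a number 52 percentage points lower from compound 1 to compound 4 (beyond the scatter) came with acetyl in place of hydrogen on the nitrogen and gives the first measured cost of that acetyl, showing that the amino group of compound 1 does not keep its effect once this nitrogen is acylated, just as it does not when aminomethyl takes its place in compound 3. No measurement available here explains why either change has the effect it does.

As far as these compounds go, what stays open is whether a smaller or different substituent on this nitrogen, such as a single methyl, a formyl or a methanesulfonyl group, would retain more of the effect of compound 1 than acetyl does. From the compounds shown here alone, it is also open whether acetyl would cost as much with hydrogen in place of the neighbouring methyl, as in compound 2.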